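This account rests on a few compounds, and the source may have more. Where it says the series, first, only, none or still open, it means among the compounds named here.

Of the compounds shown here, three of one series have been measured in a functional assay on SW-620 cells (Homo sapiens) for inhibition, read by MTT assay, with a stated time of 48 h; a higher number here means a weaker inhibitor, a lower number a stronger inhibitor. Compound 1 `Cc1ccc(NC(=O)NC(=O)c2ccc(OCc3ccccc3)cc2)cc1-c1nc2ccccc2[nH]1` gives 30100 nM. Compound 2 `Cc1ccc(NC(=O)NC(=O)c2ccc(OCc3ccc(C(F)(F)F)cc3)cc2)cc1-c1nc2ccccc2[nH]1` gives 15300 nM in this assay, and the step from the first to the second is a 2.0-fold lower number from compound 1 to compound 2 (0.29 log units; within the scatter). Compound 3 `Cc1ccc(NC(=O)NC(=O)c2ccc(OCc3cccc(Cl)c3Cl)cc2)cc1-c1nc2ccccc2[nH]1` gives 42100 nM in this assay, the highest of the three numbers; the steps leading to it read a 1.4-fold higher number from compound 1 to compound 3 (0.15 log units; within the scatter) and a 2.8-fold higher number from compound 2 to compound 3 (0.44 log units; beyond the scatter).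

Compound 4 `Cc1ccc(NC(=O)NC(=O)c2ccc(OCc3ccccc3Cl)cc2)cc1-c1nc2ccccc2[nH]1` has not yet been measured. Relative to compound 3 it carries hydrogen in place of chloro on an aromatic carbon. The measured step that bears on this is a 1.4-fold higher number from compound 1 to compound 3 (0.15 log units; within the scatter), where phenyl becomes 2,3-dichlorophenyl and the number stays within the scatter. Taking one chloro away again is a smaller change of the same kind, and no step beyond the scatter is expected in this assay. The estimate for compound 4 in this assay is 35000 nM, with a range of 15000 nM to 80000 nM. The expected step is a 1.2-fold lower number from compound 3 to compound 4 (0.08 log units; within the scatter).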

Compound 4, half-maximal inhibitory concentration: 35700 nM
Compound 4: middle estimate off by 1.0-fold (0.01 log units), on the low side, within the range that was stated.
By their numbers in this assay, from the lowest: compounds 2, 1, 4 and 3 (each within the scatter of the next, the first and the last beyond it).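

In this assay the chloro on the aromatic carbon ortho to a chloro group can give way to hydrogen without a step beyond the scatter (a 1.2-fold lower number from compound 3 to compound 4 (0.07 log units; within the scatter)). The remaining chloro also stays within the scatter when set against hydrogen (a 1.2-fold higher number from compound 1 to compound 4 (0.07 log units; within the scatter)), so neither chloro separates these compounds here. The exchange of 4-(trifluoromethyl)phenyl for 2-chlorophenyl does go beyond the scatter, though modestly (a 2.3-fold higher number from compound 2 to compound 4 (0.37 log units; beyond the scatter)), as the exchange for 2,3-dichlorophenyl did.

No measurement at hand gives a reason for any of these steps. Still open, going by these compounds, is whether a group of another kind on this aromatic ring, such as a methoxy group, an amine or a carboxylic acid, would move the number beyond the scatter from that of the unsubstituted phenyl.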